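The source may report more compounds than this note shows. Statements on the series, on what has been measured and on what is new or still open speak of the compounds shown alone.

Working notes on the series in a functional assay on Malme-3M cells (Homo sapiens) for inhibition, read by sulforhodamine B assay, with a stated time of 48 h, tested at 1 uM; on this read-out higher numbers stand for a weaker effect at the one concentration tested and lower numbers for a stronger effect.

Compound 3 `COc1cc(Cl)cc(-c2nn(-c3cccc(NC(=O)Nc4ccc(Cl)c(Cl)c4)c3)cc2-c2ccncc2)c1` gives 77%, the highest of the three numbers measured. Within the data shown here, compound 1 `O=C(Nc1cccc(-n2cc(-c3ccncc3)c(-c3cc(O)cc(Cl)c3)n2)c1)Nc1ccc(Cl)c(Cl)c1` gives 76%, and the only step between compounds differing in one place, a number 1 percentage points higher from compound 1 to compound 3 (within the scatter), lies within the scatter. Among the measured compounds shown here, compound 2 `COc1cc(Cl)cc(-c2nn(-c3cccc(NC(=O)Nc4cc(C(F)(F)F)cc(C(F)(F)F)c4)c3)cc2-c2ccncc2)c1` gives 36%, a number well below that of compound 3; no single-change step connects these two, so only the two values themselves can be compared.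

Compound 4 `COc1cc(Cl)cc(-c2nn(-c3cccc(NC(=O)c4cccc(C(F)(F)F)c4)c3)cc2-c2ccncc2)c1` has not been measured. It differs from compound 3 by 3-(trifluoromethyl)phenyl in place of (3,4-dichlorophenyl)amino on a carbonyl carbon. For the measured compounds named here, no measured step bears on this change: the one step known concerns methyl in place of hydrogen on an oxygen on an aromatic ring, elsewhere in the molecule, and says nothing about the carbonyl side. The lower number of compound 2, which also carries trifluoromethyl groups on the terminal ring, is the only hint, and it is not a single-change comparison. The expected step is therefore a number 15 percentage points lower from compound 3 to compound 4 (beyond the scatter), small and uncertain in direction. Compound 4 is estimated at 62%, within 30% to 92%.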

Compound 4, a percentage reported as activity, at one concentration (the size of the read-out at that concentration, not a potency): 82%
Beside the measured number, compound 4's estimate is 20 percentage points below it; measured number inside the range.
By their numbers in this assay, from the lowest: compound 2; then compounds 1, 3 and 4 (each within the scatter of the next).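

In this assay, among these compounds, the change on the carbonyl carbon gives a number 5 percentage points higher from compound 3 to compound 4 (within the scatter), the first single-change step on this side of the molecule. At this position, 3-(trifluoromethyl)phenyl in place of (3,4-dichlorophenyl)amino removes the hydrogen-bond donor of the leaving group, yet the step stays within the scatter, so this pair shows no dependence of the read-out on that exchange. Nothing available gives a cause for this result.

Going by these compounds, whether a morpholine, a carboxylic acid or a longer alkyl chain on this carbonyl carbon would give a number beyond the scatter remains open. On these data alone, compound 2 still has no single-change neighbour, so what sets its value apart also remains open.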